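A few compounds are considered here, and "the series" means these few. Any claim that something is new, unique, unknown or untested is made for them only; others in the source may bear on it.

Of the compounds shown here, three sharing one core have been tested in an ADME assay on MT4 cells (Homo sapiens) for cytotoxicity, read by MTT assay, with a stated time of 4 days; on this read-out lower numbers stand for higher toxicity in this test and higher numbers for lower toxicity in this test. Compound 1 `CCOC(=O)c1cnc(N2CCN(Cc3ccc(Br)cc3)CC2)nc1Oc1c(C)cc(-c2ccc(C#N)cc2)cc1C` carries a 4-bromophenyl group on the arm attached to the ring amine; in this assay compound 1 gives > 125000 nM, which is a limit of the test rather than a number. Compound 2 `CCOC(=O)c1cnc(N2CCN(Cc3cc(F)cc(F)c3)CC2)nc1Oc1c(C)cc(-c2ccc(C#N)cc2)cc1C` gives > 125000 nM in this assay, again a limit. Compound 3 `CCOC(=O)c1cnc(N2CCN(Cc3ccc(S(N)(=O)=O)cc3)CC2)nc1Oc1c(C)cc(-c2ccc(C#N)cc2)cc1C` gives >= 7930 nM in this assay, also a limit. With limits on both sides, the steps a step that the two limits leave unreadable from compound 1 to compound 3 and a step that the two limits leave unreadable from compound 2 to compound 3, like a step that the two limits leave unreadable from compound 1 to compound 2, cannot be read in size. Compound 4 `CCOC(=O)c1cnc(N2CCN(Cc3cc(C)cc(C)c3)CC2)nc1Oc1c(C)cc(-c2ccc(C#N)cc2)cc1C` differs from compound 3 by 3,5-dimethylphenyl in place of 4-sulfamoylphenyl on a saturated chain carbon bound to an amine nitrogen in a ring. Among the measured compounds shown here, no measured step bears on this change with a readable size; what can be said is that the two compounds without a sulfamoyl group both sit at the limit of > 125000 nM in this assay, at which 2 of the 3 values shown sit, while compound 3 alone sits at the limit of >= 7930 nM in this assay, at which 1 of the 3 values shown sits. Compound 4 is therefore expected to give a limit as well, and the step that the limit leaves unreadable from compound 3 to compound 4 is expected to run toward lower toxicity. The estimate for compound 4 is 125000 nM, in a range from 20000 nM to 300000 nM, with the test most likely reporting only a limit.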

Compound 4, half-maximal cytotoxic concentration: > 125000 nM
Compound 4 gave a limit, no number; the forecaster's own chance of this, stated with the estimate: 80%; the middle value sits exactly at the limit.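

In this assay compound 4 gives > 125000 nM, which is a limit and not a number. Comparing compound 4 with compound 1, compound 2 or compound 3 sets one limit against another, so no new step can be read in size. The compounds shown leave open the actual half-maximal cytotoxic concentration of all four compounds, and how far they differ.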